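Replacing the 3,4-dimethoxyphenyl of compound 3 with cyclohexyl

The compounds below may be only part of what the source reports. "The series", "measured", "known", "first", "only" and "open" are said of these compounds alone.

compound 1 `Brc1ccc2[nH]cc(C(c3ccccc3)c3c[nH]c4ccc(Br)cc34)c2c1`: 900 nM
compound 2 `Oc1cccc(C(c2c[nH]c3ccc(Br)cc23)c2c[nH]c3ccc(Br)cc23)c1`: 3900 nM
compound 3 `COc1ccc(C(c2c[nH]c3ccc(Br)cc23)c2c[nH]c3ccc(Br)cc23)cc1OC`: 6100 nM

All three values come from a functional assay on HeLa cells (Homo sapiens) for inhibition, read by MTT assay, with a stated time of 48 h; a higher number here means a weaker inhibitor, a lower number a stronger inhibitor. Compound 3 gives 6100 nM there. Its nearest neighbour is reached by a step that does not separate the pair: a 1.6-fold higher number from compound 2 to compound 3 (0.19 log units; within the scatter). Its furthest neighbour lies clearly apart: a 6.8-fold higher number from compound 1 to compound 3 (0.83 log units; beyond the scatter).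

Compound 4 `Brc1ccc2[nH]cc(C(c3c[nH]c4ccc(Br)cc34)C3CCCCC3)c2c1` differs from compound 3 on the saturated chain carbon bound to two aromatic carbons: cyclohexyl in place of 3,4-dimethoxyphenyl on a saturated chain carbon bound to two aromatic carbons. Among the compounds with values here, no measured compound has a non-aromatic ring at this carbon, so the evidence is indirect. Within the data shown here, two measured steps bear on it, both modest and both starting from the plain phenyl of compound 1: a 4.3-fold higher number from compound 1 to compound 2 (0.64 log units; beyond the scatter) and a 6.8-fold higher number from compound 1 to compound 3 (0.83 log units; beyond the scatter). Cyclohexyl, like that phenyl, carries no substituent, so a modest move back towards compound 1 is expected. The expected step is a 3.1-fold lower number from compound 3 to compound 4 (0.48 log units; beyond the scatter). For compound 4 the estimated value is 2000 nM, with an expected range of 600 nM to 7000 nM.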

Compound 4, half-maximal inhibitory concentration: 3200 nM
Compound 4: middle estimate off by 1.6-fold (0.20 log units), on the low side, within the range that was stated.
By their numbers in this assay, from the lowest: compound 1; then compounds 4, 2 and 3 (each within the scatter of the next).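

In this assay the steps of a 1.9-fold lower number from compound 3 to compound 4 (0.28 log units; within the scatter) and a 1.2-fold lower number from compound 2 to compound 4 (0.09 log units; within the scatter) both stay within the scatter, so at this carbon a non-aromatic ring is not told apart from 3,4-dimethoxyphenyl or 3-hydroxyphenyl. Only the plain phenyl stands apart, with a 3.6-fold higher number from compound 1 to compound 4 (0.55 log units; beyond the scatter) as its step, so among these compounds a ring without a substituent does not by itself bring back the value of compound 1. Nothing available accounts for this gap between phenyl and cyclohexyl.

From the compounds shown here alone, it remains open whether another group on this carbon, such as cyclopentyl, a butyl chain, or a phenyl carrying an amine or a carboxylic acid, would match or pass phenyl. Also open, going by these compounds, is whether the standing of phenyl would hold if the bromine atoms on the shared core gave way to chlorine or hydrogen.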